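Replacing piperidin-1-yl with 3-oxopiperazin-1-yl: working notes

The source may hold more compounds than are shown below. What is called first, only, known or untested is meant among the compounds shown, and "the series" means these compounds.

Values so far in an in vitro ADME assay on microsomes from liver (Homo sapiens) for metabolic stability; a lower number here means slower removal, a higher number faster removal of the compound
- compound 1 `CC(C)NC(=O)[C@H]1CC[C@@H](n2/c(=N/C(=O)c3ccc(F)cc3)[nH]c3ccc(CN4CCC[C@H]4C(C)(C)O)cc32)CC1` gives 569 mL.min-1.g-1
- compound 2 `CC(C)NC(=O)[C@H]1CC[C@@H](n2/c(=N/C(=O)c3ccc(F)cc3)[nH]c3ccc(CN4CCCCC4)cc32)CC1` gives 302 mL.min-1.g-1

Within the data shown here, compound 2 stands within the scatter of compound 1, the only other number, so neither compound leads. Compound 3 `CC(C)NC(=O)[C@H]1CC[C@@H](n2/c(=N/C(=O)c3ccc(F)cc3)[nH]c3ccc(CN4CCNC(=O)C4)cc32)CC1` differs from compound 2 by 3-oxopiperazin-1-yl in place of piperidin-1-yl on a saturated chain carbon bound to an aromatic carbon on a saturated chain carbon bound to an aromatic carbon. Among the measured compounds shown here, the only measured step at that place is a 1.9-fold lower number from compound 1 to compound 2 (0.28 log units; within the scatter) and it involves a different group, so it is a weak guide. Going by these compounds, on that single step, no change beyond the scatter is expected in this assay and the direction remains open, with a slightly lower number tentatively assumed. The expected step is a 1.4-fold lower number from compound 2 to compound 3 (0.14 log units; within the scatter) as an estimate only. For compound 3 the estimated value is 220 mL.min-1.g-1 with an expected range from 100 mL.min-1.g-1 to 450 mL.min-1.g-1 pending measurement.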

Compound 3, intrinsic clearance in microsomes: 194 mL.min-1.g-1
The estimate for compound 3 lay 1.1-fold (0.05 log units) above the measured number; low and high end bracket the measured number.
By their numbers in this assay, from the lowest: compounds 3, 2 and 1 (each within the scatter of the next, the first and the last beyond it).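

In this assay the change from piperidin-1-yl to 3-oxopiperazin-1-yl gives a 1.6-fold lower number from compound 2 to compound 3 (0.19 log units; within the scatter) and so cannot be told from no change at this place, on a saturated chain carbon bound to an aromatic carbon. Set against 2-(1-hydroxy-1-methylethyl)pyrrolidin-1-yl, the same group gives a 2.9-fold lower number from compound 1 to compound 3 (0.47 log units; beyond the scatter) and this is the first step at this place beyond the scatter, so the read-out does depend on the group carried here. Compound 2 stays within the scatter of the other two, so the three groups show a separation of the two ends and no clear ladder.

Going by these compounds, whether a morpholin-4-yl ring or an open-chain dimethylamino group at this place would take the number further from that of compound 1 remains open. No data shown bear on the reason for these steps.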